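The source may hold more compounds than are shown below. What is called first, only, known or untested is meant among the compounds shown, and "the series" means these compounds.

Compound 2, `COc1cc2cc(Oc3ccc(NC(=O)Nc4cccc(C(F)(F)F)c4)cc3)c(C)nc2cc1OC`, is studied in a functional assay on MDA-MB-435 cells (Homo sapiens) for inhibition, read by sulforhodamine B assay, with a stated time of 48 h, tested at 10 uM; on this read-out higher numbers stand for a weaker effect at the one concentration tested and lower numbers for a stronger effect. For the measured compounds named here, of the two compounds measured, compound 2 gives the lower number, 7.23%, and the only comparison at hand is compound 1, `COc1cc2cc(Oc3ccc(NC(=O)Nc4ccc(C)cc4)cc3)c(C)nc2cc1OC`, which in this assay gives 107%. Going by the values given here, the one step known, a number 99.8 percentage points lower from compound 1 to compound 2 (beyond the scatter), shows that exchanging the ring on the amide-type nitrogen can move the read-out very far. Compound 3, `COc1cc2cc(Oc3ccc(NC(=O)Nc4ccc(Cl)c(Cl)c4)cc3)c(C)nc2cc1OC`, differs from compound 2 in that same place: 3,4-dichlorophenyl in place of 3-(trifluoromethyl)phenyl on an amide-type nitrogen. Among the compounds with values here, no measured step covers this exact exchange, so the expectation rests on that one step and on the closeness of the two groups in kind. Compound 3 is therefore expected to stay near compound 2 in this assay, with the step of a number 7.8 percentage points higher from compound 2 to compound 3 (within the scatter) estimated to fall within the scatter, giving an estimated value for compound 3 of 15%, between 2% and 60%.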

Compound 3, a percentage reported as activity, at one concentration (the size of the read-out at that concentration, not a potency): 12.3%
The estimate for compound 3 lay 2.7 percentage points above the measured number; low and high end bracket the measured number.
By their numbers in this assay, from the lowest: compounds 2 and 3 (each within the scatter of the next); then compound 1.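

In this assay, a second ring on the amide-type nitrogen now also gives a low number: the result is a number 5.1 percentage points higher from compound 2 to compound 3 (within the scatter), so 3,4-dichlorophenyl and 3-(trifluoromethyl)phenyl cannot be told apart here. The step of a number 94.7 percentage points lower from compound 1 to compound 3 (beyond the scatter) repeats the large drop seen earlier, which shows that the low number at this position does not depend on the trifluoromethyl group alone, as a ring with two chlorine atoms and no fluorine reaches it too. Nothing measured here explains why these two rings behave alike while the 4-methylphenyl of compound 1 does not.

Still open, from the compounds shown here alone, is what happens when the ring on the amide-type nitrogen carries an amine or a carboxylic acid, or gives way to a longer alkyl chain. A reading at one concentration also leaves the potency of compound 2 and compound 3 unknown.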